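The source may report more compounds than this note shows. Statements on the series, on what has been measured and on what is new or still open speak of the compounds shown alone.

In an assay for binding affinity to dual specificity mitogen-activated protein kinase kinase 4 (Homo sapiens), read by KINOMEscan, tested at 100 nM (a higher number here means a weaker effect of the compound at the concentration tested, a lower number a stronger effect), compound 3 `CCCS(=O)(=O)Nc1ccc(F)c(C(=O)c2n[nH]c3ncc(-c4ccc(OC)cc4)cc23)c1F` gives 4.2%; this number sits between those of compound 2 `CCCS(=O)(=O)Nc1ccc(F)c(C(=O)c2n[nH]c3ncc(-c4ccc(F)cc4)cc23)c1F`, which gives 2.1%, and compound 1 `CCCS(=O)(=O)Nc1ccc(F)c(C(=O)c2n[nH]c3ncc(-c4cccc(F)c4)cc23)c1F`, which gives 8.2%, all within the scatter of one another. Compound 4 `CCCS(=O)(=O)Nc1ccc(F)c(C(=O)c2n[nH]c3ncc(-c4ccc(Cl)cc4Cl)cc23)c1F` differs from compound 3 by 2,4-dichlorophenyl in place of 4-methoxyphenyl on an aromatic carbon. Going by the values given here, the steps that bear on this change sit on the same aromatic carbon: a number 4 percentage points lower from compound 1 to compound 3 (within the scatter), a number 2.1 percentage points higher from compound 2 to compound 3 (within the scatter) and a number 6.1 percentage points lower from compound 1 to compound 2 (within the scatter), each within the scatter. Three different groups there have left this assay almost unchanged, so no step beyond the scatter is expected for compound 4, which is estimated to give 5% with a range from 1% to 15%. The expected step is a number 0.8 percentage points higher from compound 3 to compound 4 (within the scatter).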

Compound 4, a percentage reported as activity, at one concentration (the size of the read-out at that concentration, not a potency): 22%
Estimate against measurement, compound 4: 17 percentage points below; the measured number lies above the stated range.
By their numbers in this assay, from the lowest: compounds 2, 3 and 1 (each within the scatter of the next); then compound 4.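

In this assay, going by these compounds alone, this aromatic carbon proves sensitive to its substituent after all, as 2,4-dichlorophenyl gives the first steps at this position to lie beyond the scatter, all three modest (a number 17.8 percentage points higher from compound 3 to compound 4 (beyond the scatter); a number 19.9 percentage points higher from compound 2 to compound 4 (beyond the scatter); a number 13.8 percentage points higher from compound 1 to compound 4 (beyond the scatter)). Compound 4 alone stands apart, whichever of the other three aryl groups it is set against. No evidence is available to account for this step. The compounds shown leave open whether both chlorines are needed for it. A phenyl group carrying a single chlorine at this carbon would address that.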